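This account rests on a few compounds, and the source may have more. Where it says the series, first, only, none or still open, it means among the compounds named here.

Measured so far in a physicochemical assay for solubility, read by spectrophotometry, measured as kinetic solubility, at pH 8, tested at 500 uM; on this read-out lower numbers stand for lower solubility and higher numbers for higher solubility:

- Compound 1 `Cn1ccc2ccc(-c3cc(Nc4ccccc4S(=O)(=O)NCC4CCOCC4)cc4nccnc34)cc21` gives 2 ug/mL
- Compound 2 `CN1CCC(NC(=O)c2ccncc2Nc2cc(-c3ccc4ccn(C)c4c3)c3nccnc3c2)CC1` gives 246 ug/mL

Compound 2 holds the higher of these two numbers, and its gap to compound 1 lies well beyond the scatter of repeat measurements. Compound 3 `CC(=O)N1CCOC(CNC(=O)c2ccncc2Nc2cc(-c3ccc4ccn(C)c4c3)c3nccnc3c2)C1` differs from compound 2 in one place, on an amide-type nitrogen: (4-acetylmorpholin-2-yl)methyl stands in place of 1-methylpiperidin-4-yl (4-acetylmorpholin-2-yl)methyl in place of 1-methylpiperidin-4-yl on an amide-type nitrogen while the rest stays the same. For the measured compounds named here, compound 2 at 246 ug/mL is the higher of only two numbers, so a fall is the likelier direction in this assay for this change. The estimated change is a 4.1-fold lower number from compound 2 to compound 3 (0.61 log units; beyond the scatter) and this moderate drop is expected to lie beyond the scatter. Compound 3 is estimated at 60 ug/mL with an expected range from 10 ug/mL to 250 ug/mL as its upper end.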

Compound 3, solubility: 268 ug/mL
The estimate for compound 3 lay 4.5-fold (0.65 log units) below the measured number; the measured number lies above the stated range.
By their numbers in this assay, from the lowest: compound 1; then compounds 2 and 3 (each within the scatter of the next).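

In this assay, placing (4-acetylmorpholin-2-yl)methyl in place of 1-methylpiperidin-4-yl on the amide-type nitrogen gives a 1.1-fold higher number from compound 2 to compound 3 (0.04 log units; within the scatter). This position therefore carries either six-membered ring group with no step beyond the scatter, even though the entering group has more heavy atoms and adds an acetyl carbonyl. Nothing available here explains this result.

The compounds shown leave open whether a morpholine without the acetyl would read the same. They also leave open what a carboxylic acid or an open alkyl chain would give at this position.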